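The compounds below may be only part of what the source reports. "The series", "measured", "known", "first", "only" and "open" are said of these compounds alone.

Of the compounds shown here, three built on a shared core have numbers so far in a functional assay on MCF-10A cells (Homo sapiens) for antiproliferative activity, with a stated time of 48 h (on this read-out lower numbers stand for an effect already at smaller amounts and higher numbers for an effect only at larger amounts of compound), and they span a modest range. Compound 1 (`COc1ccc2nc(C)cc(NCc3ccncc3)c2c1`) reads 40900 nM while compound 2 (`COc1ccc2nc(C)cc(NCC3CCCN(C)C3)c2c1`) reads 6400 nM and compound 3 (`CCCOc1ccc2nc(C)cc(NCc3ccc(F)cc3)c2c1`) reads 9800 nM in the same test. Compound 3 thus sits within the usual scatter of compound 2 and clearly under compound 1.

The next compound, compound 4 (`Cc1cc(NCc2ccc(F)cc2)c2cc(OCCCCCCO)ccc2n1`), keeps everything in compound 3 except the chain on the ring oxygen, where propyl becomes 6-hydroxyhexyl (3-hydroxypropyl in place of hydrogen on a saturated chain carbon, three bonds along the chain from an oxygen on an aromatic ring). Put another way, 3-hydroxypropyl takes the place of a hydrogen at the chain end.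

For the measured compounds named here, the only measured step is a 6.4-fold lower number from compound 1 to compound 2 (0.81 log units; beyond the scatter) and it swaps pyridin-4-yl for 1-methylpiperidin-3-yl, leaving the ether chain alone. It gives no direct guide to this change and shows only that one replacement in this set can move the number by a modest amount. Going by the values given here, no measured compound carries a 6-hydroxyhexyl chain, so the data give no direction. A small step is expected, quite possibly within the scatter, and the estimated step is a 1.2-fold lower number from compound 3 to compound 4 (0.09 log units; within the scatter) for now. Compound 4 is expected at about 8000 nM with an estimated range from 2500 nM to 26000 nM in this assay once tested.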

Compound 4, half-maximal effective concentration: 8100 nM
Compound 4: the middle estimate sits 1.0-fold (0.01 log units) below what was measured, and the stated range covers the measured number.
By their numbers in this assay, from the lowest: compounds 2, 4 and 3 (each within the scatter of the next); then compound 1.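

For the compounds shown here, until this result, the only measured step lay on the other side of the shared core, at the group on the ring nitrogen, and compound 1 and compound 2 carry the same chain on the ring oxygen. Here that chain is changed for the first time, and in this assay the step is a 1.2-fold lower number from compound 3 to compound 4 (0.08 log units; within the scatter) and so the two numbers cannot be told apart. For this one pair, then, a 3-hydroxypropyl group on the saturated chain carbon, a piece of 4 heavy atoms ending in a hydroxyl, brings no readable difference, and no measurement shown offers an explanation for how closely the two compounds agree.

This change lengthens the chain and adds the end hydroxyl in a single step, so the pair cannot say whether either part matters alone or whether the two offset each other, and a plain hexyl chain would separate them. As far as these compounds go, it also remains open how the number would respond to a different group at the chain end, such as an amine or a carboxylic acid, or to a chain longer than 6-hydroxyhexyl.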